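Aryl-pyrazole acetonitriles: acetyl to dimethylamino on the phenyl

This account rests on a few compounds, and the source may have more. Where it says the series, first, only, none or still open, it means among the compounds named here.

Measured so far:
- compound 1 `COc1cc(C)cc(-c2c(-c3ccnc(-c4ccc(C(C)=O)cc4)c3)cnn2CC#N)c1`: 94%
- compound 2 `COc1cc(C)cc(-c2nn(CC#N)cc2-c2ccnc(-c3ccc(N(C)C)cc3)c2)c1`: 93%
- compound 3 `Cc1cc(O)cc(-c2nn(CC#N)cc2-c2ccnc(-c3ccc(N(C)C)cc3)c2)c1`: 94%

In a functional assay on NCI-H23 cells (Homo sapiens) for cytotoxicity, read by sulforhodamine B assay, with a stated time of 48 h, tested at 0.001 uM (a lower number here means a stronger effect, a higher number a weaker effect of the compound at the concentration tested), compound 1 gives 94%, level with compound 3 at the digits shown and together the highest of the three numbers; compound 2 lies a single point lower, within the scatter. For the measured compounds named here, the only single-point step in the set, a number 1 percentage points higher from compound 2 to compound 3 (within the scatter), is also within the scatter. All three numbers sit in the same narrow band, so the series shows no effect that separates its members at this concentration.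

Compound 4 `COc1cc(C)cc(-c2c(-c3ccnc(-c4ccc(N(C)C)cc4)c3)cnn2CC#N)c1` is compound 1 with dimethylamino in place of acetyl on an aromatic carbon. Going by the values given here, no measured pair isolates this change against compound 1, but both compounds that carry the dimethylamino group entering here sit in the same band as the acetyl compound: compound 2 gives 93%, and compound 3 gives 94%. No movement beyond the scatter is therefore expected for compound 4 in this assay, and the step of a number 1 percentage points lower from compound 1 to compound 4 (within the scatter) is estimated as flat. The value for compound 4 is expected near 93%, between 84% and 100%.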

Compound 4, a percentage reported as activity, at one concentration (the size of the read-out at that concentration, not a potency): 86%
Compound 4: the middle estimate sits 7 percentage points above what was measured, within the range that was stated.
By their numbers in this assay, from the lowest: compounds 4, 2, 1 and 3 (each within the scatter of the next).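

In this assay, the change on the aromatic carbon para to a large group now has a direct reading: a number 8 percentage points lower from compound 1 to compound 4 (within the scatter), so dimethylamino in place of acetyl does not separate the two compounds at this concentration. Compound 2 and compound 3 could not show this, as neither differs from compound 1 in this one place alone. No measured property bears on this result, and the step carries no explanation.

From the compounds shown here alone, whether a carboxylic acid or a longer amine chain at this position would move the read-out beyond the scatter remains open. So does how compound 1 and compound 4 compare at concentrations other than this one.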